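Nitrofuran Amides: Tolerability on Vero Cells and a Biaryl Analogue

The compounds below may be only part of what the source reports. "The series", "measured", "known", "first", "only" and "open" are said of these compounds alone.

Compound 1 `O=C(NCc1cccc(Cl)c1)c1ccc([N+](=O)[O-])o1`: 5500 nM
Compound 2 `O=C(NC(=O)c1ccc([N+](=O)[O-])o1)c1ccccc1`: 3000 nM
Compound 3 `COc1ccc(C(C)(C)NC(=O)c2ccc([N+](=O)[O-])o2)cc1`: 82000 nM

Three amides sharing the core of compound 1 were tested in an ADME assay on Vero cells (Chlorocebus sabaeus) for cytotoxicity, read by MTT assay, with a stated time of 48 h; a lower number here means that less compound is tolerated, a higher number that more compound is tolerated. Compound 1 gives 5500 nM in this assay, and compound 2 gives 3000 nM. Compound 3 gives 82000 nM, the highest of the three numbers; the gaps to compound 1 and to compound 2 both lie beyond the scatter, so compound 3 is the best tolerated of the set.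

Compound 4 `CC(C)(NC(=O)c1ccc([N+](=O)[O-])o1)c1ccc(-c2ccc(Cl)cc2)cc1` has not yet been measured in this assay. It differs from compound 3 in one place: 4-chlorophenyl in place of methoxy on an aromatic carbon, para to a large group. Among the measured compounds shown here, no measured pair in this set isolates such a change, so the expectation rests on the spread of the three values alone.

The account expects the number for compound 4 to fall below that of compound 3, by a step beyond the scatter, given that compound 1 gives 5500 nM and compound 2 gives 3000 nM while compound 3 stands apart at 82000 nM. The expected step is a 5.5-fold lower number from compound 3 to compound 4 (0.74 log units; beyond the scatter). Compound 4 is estimated at 15000 nM, with a range from 4000 nM to 50000 nM.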

Compound 4, half-maximal cytotoxic concentration: > 140000 nM
Compound 4: a limit, no number (the forecaster's own chance of this, stated with the estimate: 10%); middle value at least 9.3-fold (0.97 log units) away from the limit.
By their numbers in this assay, from the lowest: compounds 2 and 1 (each within the scatter of the next); then compound 3. At a limit, above all of these: compound 4.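

In this assay compound 4 gives > 140000 nM, which is a limit of the assay and not a number. Among the compounds shown here, this is the first comparison in the set that isolates a change in one place, and on an aromatic carbon para to a large group, 4-chlorophenyl in place of methoxy gives an at least 1.7-fold higher number from compound 3 to compound 4 (0.23 log units; that floor lies within the scatter), so the larger group, with its additional six-membered aromatic ring and its chlorine, brought no drop in the number, although the floor of the step does not by itself establish a rise beyond the scatter. The earlier compounds could show only that compound 3 stood apart from the other two, whereas this pair shows that the position accepts the exchange while the reading stays at the top of what the assay reports, and the true size of the step remains unknown: the limit of > 140000 nM in this assay, at which 1 of the 4 values shown sits.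

Whether the ring alone or the chlorine on it accounts for this result stays open, since the compounds shown include no plain phenyl at this position. How an amine, a carboxylic acid or a longer chain at the same position would read in this assay is also left open.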